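A few compounds are considered here, and "the series" means these few. Any claim that something is new, unique, unknown or untested is made for them only; others in the source may bear on it.

Measured so far:
compound 1 `CCCOC(=O)C1=C(C)NC(=O)NC1c1ccco1`: 3%
compound 2 `CCCOC(=O)C1=C(C)NC(=O)NC1c1cccs1`: 32%
compound 3 `CCCOC(=O)C1=C(C)N(C)C(=O)NC1c1ccco1`: 8%

In an assay on membranes from HeLa cells for displacement of a labelled ligand from adenosine receptor A3 (Homo sapiens), read by scintillation counting, with a stated time of 180 min, tested at 1 uM (a higher number here means more inhibition at the concentration tested (going by the name of the read-out), a lower number less inhibition), compound 1 gives 3%, the lowest of the three numbers. Compound 3 lies nearest, a number 5 percentage points higher from compound 1 to compound 3 (within the scatter), a change of methyl in place of hydrogen on an amide-type nitrogen in a ring that does not move the read-out. Compound 2 lies furthest, a number 29 percentage points higher from compound 1 to compound 2 (beyond the scatter), for thiophen-2-yl in place of furan-2-yl on a saturated ring carbon.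

Compound 4 `CC1=C(C(=O)OCC2CC2)C(c2ccco2)NC(=O)N1` differs from compound 1 by cyclopropyl in place of ethyl on a saturated chain carbon bound to an oxygen next to a carbonyl group. Neither measured step touches this part of the molecule: the step to compound 2 alters the aromatic group on the saturated ring carbon, the step to compound 3 the ring nitrogen. Within the data shown here, no measured step therefore bears on the ester chain, and the two known steps give no lead on its direction. With the rest of compound 1 kept and its value at 3%, the expectation for compound 4 is for no step beyond the scatter, a number 2 percentage points higher from compound 1 to compound 4 (within the scatter). The estimate for compound 4 in this assay is 5%, with a range from -6% to 18%.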

Compound 4, a percentage reported as inhibition, at one concentration (the size of the read-out at that concentration, not a potency): 1%
For compound 4 the middle estimate is 4 percentage points above the measured one; the range from low to high includes it.
By their numbers in this assay, from the lowest: compounds 4, 1 and 3 (each within the scatter of the next); then compound 2.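

In this assay the ester chain gets its first reading: a number 2 percentage points lower from compound 1 to compound 4 (within the scatter), so going from propyl to cyclopropylmethyl adds a three-membered ring without a step that can be told from the scatter. The reading is limited, since compound 1 stands at 3% and a fall at this position would have little room to show on this read-out. Nothing measured here bears on why the read-out stays put.

As far as these compounds go, whether the same change would hold on the thiophen-2-yl compound 2, at 32%, where a fall could show, remains open. Also open, from the compounds shown here alone, is whether a longer chain, a benzyl group or a chain carrying an amine at this ester position would give a step beyond the scatter in either direction.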